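A few compounds are considered here, and "the series" means these few. Any claim that something is new, unique, unknown or untested is made for them only; others in the source may bear on it.

Compound 3 `CC(C)N(Cc1cccc(OCCCCCC(=O)O)c1)C(=O)c1ccc(-c2ccc3c(c2)OCCO3)cc1` carries a 2,3-dihydro-1,4-benzodioxin-6-yl group on an aromatic carbon of the shared core. In an ADME assay on HepG2 cells (Homo sapiens) for cytotoxicity, read by CellTiter-Glo and resazurin assay, with a stated time of 72 h (on this read-out higher numbers stand for an effect only at larger amounts of compound and lower numbers for an effect already at smaller amounts), compound 3 gives only a limit, > 21900 nM, and no number. Compound 1 `CC(C)N(Cc1cccc(OCCCCCC(=O)O)c1)C(=O)c1ccc(-c2cccc(N(C)C)c2)cc1`, which bears 3-(dimethylamino)phenyl at that place, likewise reaches only a limit, > 26000 nM. Compound 2 `CC(C)N(Cc1cccc(OCCCCCC(=O)O)c1)C(=O)c1ccc(-c2cccc3ccccc23)cc1`, with naphthalen-1-yl there, also gives a limit, > 26000 nM. Compound 3 therefore stands where the other two stand, at the edge of what this assay can read, marked by the limit of > 21900 nM in this assay, at which 1 of the 3 values shown sits, and by the limit of > 26000 nM in this assay, at which 2 of the 3 values shown sit.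

The measured steps among these three are a step that the two limits leave unreadable from compound 1 to compound 2, a step that the two limits leave unreadable from compound 1 to compound 3 and a step that the two limits leave unreadable from compound 2 to compound 3. None of them carries a readable size, so no direction for a change of the aromatic group can be drawn from them.

Compound 4 `COc1ccc(F)c(-c2ccc(C(=O)N(Cc3cccc(OCCCCCC(=O)O)c3)C(C)C)cc2)c1` differs from compound 3 by 2-fluoro-5-methoxyphenyl in place of 2,3-dihydro-1,4-benzodioxin-6-yl on an aromatic carbon. Since the three measured steps yield no readable size, the expectation for the step in this assay from compound 3 to compound 4 is a step that the limit leaves unreadable from compound 3 to compound 4, nothing beyond the scatter. Compound 4 is accordingly estimated at 30000 nM in this assay, within a range from 15000 nM to 60000 nM, with a considerable chance that only a limit is reported again.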

Compound 4, half-maximal effective concentration: > 26000 nM
Compound 4: only a limit was reported; the forecaster's own chance of this, stated with the estimate: 80%; the middle value does not contradict the limit.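

In this assay compound 4 gives only a limit, > 26000 nM. The steps to it from compound 1, compound 2 and compound 3 all lie between limits, and none of them can be read. The compounds shown leave open at what concentration any of them would act in this assay, and whether the aromatic group changes that concentration.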